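Chloro for hydroxy on the aryl ring of compound 3

The source may hold more compounds than are shown below. What is called first, only, known or untested is meant among the compounds shown, and "the series" means these compounds.

Of the compounds shown here, three sharing one core have been tested in a functional assay on HL-60 cells (Homo sapiens) for cytotoxicity, read by WST assay, with a stated time of 48 h; on this read-out lower numbers stand for an effect already at smaller amounts and higher numbers for an effect only at larger amounts of compound. Compound 1 `COc1ccccc1C[C@H]1C(=O)OC[C@@H]1Cc1ccccc1` gives 79000 nM in this assay. Compound 2 `CCCCCCCOc1ccccc1C[C@H]1C(=O)OC[C@@H]1Cc1ccccc1` gives 75000 nM in this assay. Within the data shown here, the single measured step, a 1.1-fold lower number from compound 1 to compound 2 (0.02 log units; within the scatter), is within the scatter and concerns a hexyl in place of hydrogen on a saturated chain carbon bound to an oxygen on an aromatic ring. Compound 3 `O=C1OC[C@H](Cc2ccccc2)[C@H]1Cc1cccc(O)c1` stands apart from the two others: in this assay compound 3 reaches only a limit, > 100000 nM, so no number is known for it, and it sits at the limit of > 100000 nM in this assay, at which 1 of the 3 values shown sits.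

The next compound, compound 4 `O=C1OC[C@H](Cc2ccccc2)[C@H]1Cc1cccc(Cl)c1`, differs from compound 3 in one place: chloro in place of hydroxy on an aromatic carbon. Among the measured compounds shown here, no measured step touches this aromatic carbon, meta to a large group, and the one step that exists, on the alkoxy chain, was within the scatter; it gives no guidance on a chloro in place of a hydroxy. Compound 3 itself supplies only a limit.

With nothing pointing in either direction, compound 4 is expected to remain near where compound 3 stands, with a step of about an at least 1.1-fold lower number from compound 3 to compound 4 (0.04 log units; that floor lies within the scatter). The estimated value of compound 4 in this assay is 90000 nM, with a range from 35000 nM to 250000 nM.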

Compound 4, half-maximal effective concentration: 36000 nM
Compound 4: the middle estimate sits 2.5-fold (0.40 log units) above what was measured; low and high end bracket the measured number.
By their numbers in this assay, from the lowest: compound 4; then compounds 2 and 1 (each within the scatter of the next). At a limit, above all of these: compound 3.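

Going from 3-hydroxyphenyl to 3-chlorophenyl gives an at least 2.7-fold lower number from compound 3 to compound 4 (0.44 log units; beyond the scatter) in this assay, and this is the first step among these compounds that lies beyond the scatter. The earlier step, on the alkoxy chain, showed no readable change, whereas this aromatic carbon, meta to a large group, shows that the read-out does respond to what this position carries. The step can be read only as a floor and not as a full size, because compound 3 stands at a limit of the assay: the limit of > 100000 nM in this assay, at which 1 of the 4 values shown sits.

Going by these compounds, whether the change comes from the arrival of the chloro or from the departure of the hydroxy stays open, as this single pair cannot separate the two, and a fluoro, a methyl, a methoxy or a nitrile on the same aromatic carbon would help to tell them apart. Also open, on these data alone, is whether a chloro on the other aromatic ring, the phenyl that stays unchanged in all four compounds, would give a step of its own in this read-out.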